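From 6-methoxypyridin-3-yl to 3,4-dichlorophenyl on the shared core

The source may report more compounds than this note shows. Statements on the series, on what has been measured and on what is new or still open speak of the compounds shown alone.

Compound 1 (`COc1ccc(C(=O)/C=C/c2ccccc2)c2c1C=CC(C)(C)O2`) carries phenyl on the chain. In a functional assay on HT-29 cells (Homo sapiens) for antiproliferative activity, read by MTT assay, with a stated time of 24 h (on this read-out lower numbers stand for stronger inhibition and higher numbers for weaker inhibition), compound 1 gives > 10000 nM as a limit of the assay. Compound 2 (`COc1ccc(/C=C/C(=O)c2ccc(OC)c3c2OC(C)(C)C=C3)cn1`) carries 6-methoxypyridin-3-yl at that place. In this assay compound 2 gives > 10000 nM as a limit too, so compound 2 has no number to start from. For the measured compounds named here, the series so far offers only this ceiling (the limit of > 10000 nM in this assay, at which 2 of the 2 values shown sit). Going by the values given here, the one measured step is a step that the two limits leave unreadable from compound 1 to compound 2 and gives no size to carry forward.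

Compound 3 (`COc1ccc(C(=O)/C=C/c2ccc(Cl)c(Cl)c2)c2c1C=CC(C)(C)O2`) replaces the pyridine-bearing group with 3,4-dichlorophenyl on a double-bonded chain carbon bound to a double-bonded chain carbon (3,4-dichlorophenyl in place of 6-methoxypyridin-3-yl on a double-bonded chain carbon bound to a double-bonded chain carbon). On these data alone, no measured step sizes this replacement, so no particular shift is expected in this assay and the direction stays open. The expected move is a number no higher from compound 2 to compound 3 (the limit leaves the size open) as a rough estimate against a limit. The estimate for compound 3 is 10000 nM with an expected range of 3000 nM to 30000 nM and a fair expectation that only a limit is reported.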

Compound 3, half-maximal inhibitory concentration: 7580 nM
Compound 3: the middle estimate sits 1.3-fold (0.12 log units) above what was measured; low and high end bracket the measured number.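

In this assay, for the compounds shown here, compound 3 gives 7580 nM, the first value that is a number and not a limit, so this place on the chain now has one group with a readable result. Against the two limits, the replacement reads as an at least 1.3-fold lower number from compound 2 to compound 3 (0.12 log units; that floor lies within the scatter) and, from the unsubstituted phenyl, as an at least 1.3-fold lower number from compound 1 to compound 3 (0.12 log units; that floor lies within the scatter); these are floors only, so they show that the true steps could be larger but do not establish a shift beyond the usual scatter. With 3,4-dichlorophenyl at this place the series has left the ceiling at only one point, and the other two compounds remain there: the limit of > 10000 nM in this assay, at which 2 of the 3 values shown sit.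

On these data alone, how far compounds 1 and 2 actually lie from compound 3 stays open, and so does whether both chlorine atoms are needed for a measurable number or a single chlorine on the phenyl would give one too. The compounds shown also leave open what a group of another kind would do at this place, such as a phenyl bearing an amine or a carboxylic acid.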